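This account rests on a few compounds, and the source may have more. Where it says the series, first, only, none or still open, it means among the compounds named here.

Compound 2, `Cc1cccc(-c2noc([C@H](C)NC(=O)c3cc(C(F)(F)F)nn3C)n2)n1`, sits at the edge of what an assay on T-REx-293 cells for inhibition of potassium channel subfamily T member 1 (Homo sapiens), read by patch clamp (on this read-out lower numbers stand for stronger inhibition and higher numbers for weaker inhibition), can report: in this assay compound 2 gives > 30000 nM, which is a limit of the assay and not a number. Going by the values given here, its only measured neighbour is compound 1, `C[C@H](NC(=O)c1cc(C(F)(F)F)nn1C)c1nc(-c2cccc(F)c2)no1`, which in this assay gives 136 nM; the step of an at least 220-fold higher number from compound 1 to compound 2 (2.34 log units; beyond the scatter) is the one change in the same position that has been measured, and the limit of > 30000 nM in this assay, at which 1 of the 2 values shown sits, is the only evidence that bears on it. Compound 3, `CO[C@@H](C)c1cc(-c2noc([C@H](C)NC(=O)c3cc(C(F)(F)F)nn3C)n2)ccn1`, changes that same position again: a group of 10 heavy atoms (8 carbon, 1 nitrogen, 1 oxygen; one six-membered aromatic ring with 1 hetero atom) in place of a group of 7 heavy atoms (6 carbon, 1 nitrogen; one six-membered aromatic ring with 1 hetero atom), on an aromatic carbon. Both the group that leaves and the group that enters carry a six-membered aromatic ring with one hetero atom, so the measured step gives no firm direction for this change. Compound 3 is therefore expected to stay weak, with a step of an at least 1.5-fold lower number from compound 2 to compound 3 (0.17 log units; that floor lies within the scatter) as the estimate. For compound 3 the estimated value in this assay is 20000 nM, between 2000 nM and 100000 nM.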

Compound 3, half-maximal inhibitory concentration: 744 nM
Estimate against measurement, compound 3: 27-fold (1.43 log units) above, and the stated range ends above it.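

In this assay, a six-membered aromatic ring with 1 hetero atom on this aromatic carbon does not by itself rule out inhibition, as the group in compound 3 shows with an at least 40-fold lower number from compound 2 to compound 3 (1.60 log units; beyond the scatter). That group does not match the 3-fluorophenyl group of compound 1, however, and the comparison gives a 5.5-fold higher number from compound 1 to compound 3 (0.74 log units; beyond the scatter). The value of compound 2 is a limit and not a number, so the first of these steps is only a floor: the limit of > 30000 nM in this assay, at which 1 of the 3 values shown sits.

The compounds shown leave open which part of the entering group carries the step, and whether its defined stereocentre plays any part in it. Also open, going by these compounds, is how an amine, a carboxylic acid or a longer chain on the same six-membered ring would read in this assay.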